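This account rests on a few compounds, and the source may have more. Where it says the series, first, only, none or still open, it means among the compounds named here.

Compound 1, `CCCCCCCCCCCCCCc1nc(OC2CCC2)nc(OC2CCC2)c1O`: 94%. Compound 2, `CCCCCCCCCCCCCCCCc1nc(OC2CCC2)nc(OC2CCC2)c1O`: 96%. Compound 3, `CCCCCCCCCCCCCCc1nc(N2CCC2)nc(N2CCC2)c1O`: 1%.

All three values come from a functional assay on cells (Lymphocyte, Homo sapiens), read by a luciferase reporter and ATP content, with a stated time of 48 h, tested at 20 uM; a higher number here means a weaker effect of the compound at the concentration tested, a lower number a stronger effect. From compound 1 to compound 2 the change is ethyl in place of hydrogen on a saturated chain carbon, ten or more bonds along the chain from an aromatic carbon, and it made a step of a number 2 percentage points higher from compound 1 to compound 2 (within the scatter). Compound 3 stands apart: how its core differs from the core of compound 1 is not broken down here, but compound 3 gives 1%, whereas compound 1 gives 94%. Compound 4, `CCCCCCCCCCCCCCCCc1nc(N2CCC2)nc(N2CCC2)c1O`, has not yet been measured. It differs from compound 3 by ethyl in place of hydrogen on a saturated chain carbon, ten or more bonds along the chain from an aromatic carbon, the same change as that between compound 1 and compound 2. Because that earlier step was a number 2 percentage points higher from compound 1 to compound 2 (within the scatter), the expected step in this assay is a number 2 percentage points higher from compound 3 to compound 4 (within the scatter), of similar size. For compound 4 the estimate is 3%, expected to lie between 0% and 15%.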

Compound 4, a percentage reported as activity, at one concentration (the size of the read-out at that concentration, not a potency): 1%
Estimate against measurement, compound 4: 2 percentage points above; low and high end bracket the measured number.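

On the core of compound 3, in this assay, putting ethyl in place of hydrogen on the chain gives no change at the digits printed from compound 3 to compound 4 (within the scatter). Set beside the earlier step, the change behaves alike on the two cores: the same change on two cores in this assay, a number 2 percentage points higher (within the scatter) from compound 1 to compound 2 and no change at the digits printed (within the scatter) from compound 3 to compound 4, 2 percentage points apart, within the scatter of two such steps This shows that, on these two cores, the added ethyl leaves the read-out where it was, while the large gap between the two cores remains. It does not show that the same would hold on any other core, since only two are compared.

Still open, going by these compounds, is what a much shorter chain would do on either core. Also open, on these data alone, is what an amine or a carboxylic acid in place of the chain would do.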